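The compounds below may be only part of what the source reports. "The series", "measured", "known", "first", "only" and "open" are said of these compounds alone.

In an ADME assay on microsomes from liver (Homo sapiens) for metabolic stability, read by LC-MS, with a stated time of 30 min, tested at 1 uM (on this read-out lower numbers stand for a less stable compound and higher numbers for a more stable compound), compound 1 `O=C(NCc1ccc(S(=O)(=O)c2cccc(F)c2)cc1)c1cc2cnccc2[nH]1` gives 79%, compound 2 `O=C(NCc1ccc(S(=O)(=O)c2cccc(C(F)(F)F)c2)cc1)c1cc2cnccc2[nH]1` gives 81% and compound 3 `O=C(NCc1ccc(S(=O)(=O)c2ccccc2)cc1)c1cc2cnccc2[nH]1` gives 75%. Compound 3 therefore stands within the scatter of both others: a number 4 percentage points lower from compound 1 to compound 3 (within the scatter) and a number 6 percentage points lower from compound 2 to compound 3 (within the scatter). Compound 4 `Cc1cccc(S(=O)(=O)c2ccc(CNC(=O)c3cc4cnccc4[nH]3)cc2)c1` carries methyl in place of hydrogen on an aromatic carbon, meta to a large group (methyl in place of hydrogen on an aromatic carbon). Among the measured compounds shown here, no measured step involves methyl itself. The closest evidence is the two steps above, together with a number 2 percentage points higher from compound 1 to compound 2 (within the scatter), and all three stay within the scatter. No change beyond the scatter is expected, in either direction. The expected size of the change is a number 1 percentage points lower from compound 3 to compound 4 (within the scatter). For compound 4 the estimated value is 74%, with an expected range from 62% to 85%.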

Compound 4, percent of the compound remaining: 49%
Compound 4: the middle estimate sits 25 percentage points above what was measured, outside the stated range (below it).
By their numbers in this assay, from the lowest: compound 4; then compounds 3, 1 and 2 (each within the scatter of the next).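

At this position, on an aromatic carbon meta to a large group, methyl stands apart in this assay from all three other groups (a number 26 percentage points lower from compound 3 to compound 4 (beyond the scatter); a number 30 percentage points lower from compound 1 to compound 4 (beyond the scatter); a number 32 percentage points lower from compound 2 to compound 4 (beyond the scatter)), whereas hydrogen, fluoro and trifluoromethyl lie within the scatter of one another. The position is therefore not indifferent to its substituent, and a change of one heavy atom is enough to show this. Nothing available explains the result. On these data alone, it remains open whether ethyl or methoxy at this place behaves like methyl, and whether methyl on another carbon of this ring gives the same result.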